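This account rests on a few compounds, and the source may have more. Where it says the series, first, only, none or still open, it means among the compounds named here.

Working notes on the series, following the step to compound 4, `COc1cc(C2=C(c3cc(C)c(OC)c(C)c3)C(O[SiH2]C(C)(C)C)CC2=O)cc(OC)c1OC`. In an ADME assay on HEK293 cells (Homo sapiens) for cytotoxicity, read by MTT assay, with a stated time of 72 h (on this read-out higher numbers stand for weaker inhibition and lower numbers for stronger inhibition), compound 2, `COC(=O)c1cc(C2=C(c3cc(OC)c(OC)c(OC)c3)C(=O)CC2O[SiH2]C(C)(C)C)ccc1OC`, gives > 100 ug/mL, which is a limit of the assay and not a number. Compound 3, `COc1ccc(C2=C(c3cc(OC)c(OC)c(OC)c3)CC(O[SiH2]C(C)(C)C)C2=O)cc1[N+](=O)[O-]`, gives > 100 ug/mL, again a limit. Compound 1, `COc1cc(C2=C(c3cc(C)c(OC)c(C)c3)C(OC(C)=O)CC2=O)cc(OC)c1OC`, gives > 100 ug/mL, also a limit, and it already carries the 4-methoxy-3,5-dimethylphenyl group. Among the measured compounds shown here, compound 2 therefore has no number of its own and stands level with the other two, so no measured step is available to scale the change.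

The change to compound 4 is 4-methoxy-3,5-dimethylphenyl in place of 4-methoxy-3-(methoxycarbonyl)phenyl on a double-bonded ring carbon. In words, 4-methoxy-3,5-dimethylphenyl comes in place of 4-methoxy-3-(methoxycarbonyl)phenyl on a double-bonded ring carbon, with the rest of the molecule unchanged.

Compound 4 is expected to stay in the same region because of the limit of > 100 ug/mL in this assay, at which 3 of the 3 values shown sit. The expected size of a step that the limit leaves unreadable from compound 2 to compound 4 is nothing beyond the scatter, and no direction is expected. Another report of a limit is the likeliest outcome. For compound 4 the estimated value is 110 ug/mL, with an expected range of 50 ug/mL to 250 ug/mL.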

Compound 4, half-maximal inhibitory concentration: 29 ug/mL
For compound 4 the middle estimate is 3.8-fold (0.58 log units) above the measured one; the measured number lies below the stated range.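

In this assay compound 4 alone gives a measured number, while the other compounds shown remain at a limit of the assay: the limit of > 100 ug/mL in this assay, at which 3 of the 4 values shown sit. At the double-bonded ring carbon, 4-methoxy-3,5-dimethylphenyl in place of 4-methoxy-3-(methoxycarbonyl)phenyl gives an at least 3.4-fold lower number from compound 2 to compound 4 (0.53 log units; beyond the scatter), and on an oxygen on a saturated carbon, a group of 5 heavy atoms (4 carbon, 1 silicon; no ring) in place of a group of 3 heavy atoms (2 carbon, 1 oxygen; no ring) gives an at least 3.4-fold lower number from compound 1 to compound 4 (0.53 log units; beyond the scatter). Compound 1 carries the 4-methoxy-3,5-dimethylphenyl group and compound 2 carries the silicon-bearing group, yet only compound 4, with both, leaves the limit, so among these compounds neither change alone gives a measured number.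

On these data alone, the full size of each step stays open, since each starts from a limit. Also open, as far as these compounds go, is whether a free hydroxyl on that saturated carbon, or an amine or a carboxylic acid on the phenyl ring, would keep the read-out at the level of compound 4.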